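This account rests on a few compounds, and the source may have more. Where it says the series, first, only, none or still open, it means among the compounds named here.

Series notes. In an ADME assay for metabolic stability, at pH 1.5 (on this read-out higher numbers stand for a longer-lived compound and lower numbers for a shorter-lived compound), compound 1 `COc1ccc2c(c1)COP(=O)(OC[C@@H]1C=C[C@H](n3cnc4c(N)ncnc43)O1)O2` gives 0.011 h, compound 2 `OCC1CCC(n2cnc3ncnc(O)c32)O1` gives 0.03 h, and compound 3 `Cc1cccc2c1OP(=O)(OC[C@@H]1C=C[C@H](n3cnc4c(N)ncnc43)O1)OC2` gives 0.0098 h. Compound 3 stands lowest of the three numbers: its value sits within the scatter of that of compound 1, while the gap to compound 2 lies beyond the scatter. Compound 4 `Nc1ncnc2c1ncn2[C@H]1C=C[C@@H](COP2(=O)OCc3ccccc3O2)O1` is not yet run in this assay. Relative to compound 3 it carries hydrogen in place of methyl on an aromatic carbon. Among the compounds with values here, no step between measured compounds involves such a change, so nothing in the set calibrates it. The expectation is that the step of a 1.0-fold higher number from compound 3 to compound 4 (0.01 log units; within the scatter) stays within the scatter, with no fixed direction. Compound 4 is estimated at 0.01 h, with a range from 0.005 h to 0.02 h.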

Compound 4, half-life in the ADME assay: 0.01 h
Compound 4: the middle estimate sits on the measured number at the digits printed; measured number inside the range.
By their numbers in the ADME assay, from the lowest: compounds 3, 4 and 1 (each within the scatter of the next); then compound 2.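

In the ADME assay hydrogen in place of methyl (a 1.0-fold higher number from compound 3 to compound 4 (0.01 log units; within the scatter)) and hydrogen in place of methoxy (a 1.1-fold lower number from compound 1 to compound 4 (0.04 log units; within the scatter)) both stay within the scatter, so the half-life does not separate these three substituents on an aromatic carbon. In a physicochemical assay for lipophilicity (a higher number here means a more lipophilic compound, a lower number a more polar compound), compound 3 gives 0.63 and compound 4 gives 0.36 and the step (a number 0.27 log units lower from compound 3 to compound 4 (within the scatter)) also stays within the scatter. No evidence bears on these results. Going by these compounds, whether an amine, a carboxylic acid or a longer chain on that aromatic carbon would give a step beyond the scatter in the ADME assay remains open.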